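The compounds below may be only part of what the source reports. "The series", "measured", "known", "first", "only" and "open" are said of these compounds alone.

Measured so far in an ADME assay on MRC5 cells (Homo sapiens) for cytotoxicity, read by MTT assay, with a stated time of 72 h; a lower number here means a stronger inhibitor, a higher number a weaker inhibitor:
compound 1 `O=C(Nc1nnc(-c2cccc(O)c2O)s1)c1ccccc1` gives 23200 nM;
compound 2 `O=C(Nc1nnc(-c2cccc(O)c2O)s1)C1CCCCC1` gives 70300 nM;
compound 3 `O=C(Nc1nnc(-c2ccc(O)c(O)c2)s1)c1ccc(Cl)cc1` gives 30600 nM.

Compound 3 stands second highest of these three numbers. Its value is nearest to that of compound 1, a gap that lies within the scatter, and furthest from compound 2, a gap beyond the scatter. Compound 4 `CC(=O)Nc1nnc(-c2ccc(O)c(O)c2)s1` has not yet been measured. It differs from compound 3 in one place: methyl in place of 4-chlorophenyl on a carbonyl carbon. Among the compounds with values here, the only measured step at the same place is a 3.0-fold higher number from compound 1 to compound 2 (0.48 log units; beyond the scatter), a change at the carbonyl carbon. That step was modest, so compound 4 is expected to differ from compound 3 by about a 1.2-fold higher number from compound 3 to compound 4 (0.09 log units; within the scatter). Compound 4 is therefore estimated at 38000 nM, in the range 15000 nM to 95000 nM.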

Compound 4, half-maximal inhibitory concentration: 58600 nM
Estimate against measurement, compound 4: 1.5-fold (0.19 log units) below; low and high end bracket the measured number.
By their numbers in this assay, from the lowest: compounds 1, 3, 4 and 2 (each within the scatter of the next, the first and the last beyond it).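

In this assay the change from 4-chlorophenyl to methyl on the carbonyl carbon gives a 1.9-fold higher number from compound 3 to compound 4 (0.28 log units; within the scatter) and so removes the aromatic ring without moving the number beyond the scatter. The earlier step at this place, a 3.0-fold higher number from compound 1 to compound 2 (0.48 log units; beyond the scatter), lay beyond the scatter, but it was read on the core of compound 1, so the two steps show this position only on separate cores. Nothing shown gives a reason for this result.

On these data alone, whether an amine, a carboxylic acid or a longer chain on this carbonyl carbon would shift the number remains open. So does whether a cyclohexyl group would give a step beyond the scatter on the core of compound 3.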